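Working notes on cytotoxicity in compounds 1 to 4

The source may hold more compounds than are shown below. What is called first, only, known or untested is meant among the compounds shown, and "the series" means these compounds.

Measured so far:
- compound 1 `COc1ccc(Sc2cn(-c3ccc4c(c3)B(O)OC4)c3ccccc23)cc1`: > 10 ug/mL
- compound 2 `O=C(NC1CCCCC1)c1cccn1-c1ccc2c(c1)B(O)OC2`: > 10 ug/mL
- compound 3 `O=C(c1ccccc1)c1ccn(-c2ccc3c(c2)B(O)OC3)c1`: > 10 ug/mL

In an ADME assay on L929 cells (Mus musculus) for cytotoxicity, read by resazurin assay, with a stated time of 72 h (on this read-out lower numbers stand for stronger inhibition and higher numbers for weaker inhibition), compound 1 gives > 10 ug/mL, which is a limit of the assay and not a number. Compound 2 gives > 10 ug/mL in this assay, again a limit. Compound 3 gives > 10 ug/mL in this assay, also a limit. For the measured compounds named here, compound 3 therefore stands where every value so far stands: the limit of > 10 ug/mL in this assay, at which 3 of the 3 values shown sit. Going by the values given here, no pair of measured compounds differs in one place, so no measured step is available.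

Compound 4 `COc1ccccc1C(=O)c1ccn(-c2ccc3c(c2)B(O)OC3)c1` differs from compound 3 by methoxy in place of hydrogen on an aromatic carbon.

With all three measured compounds at the limit, no step beyond the usual scatter is expected in this assay from compound 3 to compound 4; the expected step is a step that the limit leaves unreadable from compound 3 to compound 4. Compound 4 is expected to give about 20 ug/mL in this assay, estimated between 10 ug/mL and 50 ug/mL, most likely reported once more only as a limit.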

Compound 4, half-maximal inhibitory concentration: > 10 ug/mL
Compound 4: only a limit was reported; the forecaster's own chance of this, stated with the estimate: 85%; the middle value lies beyond the limit too.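

No step can be read from compound 3 to compound 4 in this assay, since both are reported only as limits: the limit of > 10 ug/mL in this assay, at which 4 of the 4 values shown sit.

The compounds shown leave open where any of their true values lie, and whether any change in this series gives a readable cytotoxicity value.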